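The source may hold more compounds than are shown below. What is called first, only, known or untested is meant among the compounds shown, and "the series" means these compounds.

Measured compounds:
- compound 1 `Fc1ccc(-c2nc3ccc(Br)cn3c2-c2ccnc(NC3CCCC3)n2)cc1`; in an ADME assay on Vero cells (Chlorocebus sabaeus) for cytotoxicity (a lower number here means that less compound is tolerated, a higher number that more compound is tolerated), compound 1 gives > 40000 nM, which is a limit of the assay and not a number.
- compound 2 `Fc1ccc(-c2nc3ccc(NC4CCCC4)cn3c2-c2ccnc(NC3CCCC3)n2)cc1`; in this assay compound 2 gives > 40000 nM, again a limit and not a number.

For the measured compounds named here, compound 1 therefore stands only at a limit in this assay, and the one further value shown is likewise a limit. Compound 3 `Fc1ccc(-c2nc3c(Br)cc(Br)cn3c2-c2ccnc(NC3CCCC3)n2)cc1` differs from compound 1 by bromo in place of hydrogen on an aromatic carbon. Going by the values given here, the only measured step, a step that the two limits leave unreadable from compound 1 to compound 2, concerns a different replacement and is unreadable because of the limit of > 40000 nM in this assay, at which 2 of the 2 values shown sit. No size or direction can thus be derived for the new change from the measured steps, and no step beyond the usual scatter is expected; the most likely outcome is another reading at the limit. For compound 3 the expected value is 50000 nM, with a range from 20000 nM to 120000 nM. This corresponds to an expected step that the limit leaves unreadable from compound 1 to compound 3.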

Compound 3, half-maximal cytotoxic concentration: > 40000 nM
Compound 3: only a limit was reported (the forecaster's own chance of this, stated with the estimate: 80%); the middle value lies beyond the limit too.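

No step can be read between compound 1 and compound 3 in this assay, as both values are limits and not numbers: the limit of > 40000 nM in this assay, at which 3 of the 3 values shown sit.

The compounds shown leave open at what concentration any of them becomes cytotoxic, and whether the added bromo changes that concentration.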